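Shifting a methyl on the anilide of an ACAT inhibitor

A few compounds are considered here, and "the series" means these few. Any claim that something is new, unique, unknown or untested is made for them only; others in the source may bear on it.

Measured compounds:
compound 1 `CCCCCCCCCCCCCCCCCC(=O)Nc1c(OC)cc(OC)cc1OC` 52 nM
compound 2 `CCCCCCCCCCCCCCCCC(C)(C)C(=O)Nc1c(OC)cc(OC)cc1OC` 87 nM
compound 3 `CCCCCCCCCCC(C)(C)C(=O)Nc1ccc(C)cc1C` 680 nM

In an assay on microsomes from intestine for inhibition of acyl-CoA:cholesterol acyltransferase (Oryctolagus cuniculus) (a higher number here means a weaker inhibitor, a lower number a stronger inhibitor), compound 3 gives the highest number of the three, a step beyond the scatter from both compound 1 and compound 2. Compound 4 `CCCCCCCCCCC(C)(C)C(=O)Nc1ccc(C)c(C)c1` keeps every atom of compound 3 and changes only the arrangement: 3,4-dimethylphenyl in place of 2,4-dimethylphenyl on an amide-type nitrogen. Going by the values given here, no measured pair in this set shows a like change, so the size of the step is uncertain. An increase beyond the scatter is expected, as the two strongest compounds here, compound 1 and compound 2, carry their anilide substituents in a pattern that compound 4 abandons further than compound 3 does. Compound 4 is estimated at 1500 nM (range 500 nM to 5000 nM), an expected step of a 2.2-fold higher number from compound 3 to compound 4 (0.34 log units; beyond the scatter).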

Compound 4, half-maximal inhibitory concentration: 1660 nM
Estimate against measurement, compound 4: 1.1-fold (0.04 log units) below; low and high end bracket the measured number.
By their numbers in this assay, from the lowest: compounds 1 and 2 (each within the scatter of the next); then compound 3; then compound 4.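

In this assay moving from 2,4-dimethylphenyl to 3,4-dimethylphenyl on an amide-type nitrogen gives a 2.4-fold higher number from compound 3 to compound 4 (0.39 log units; beyond the scatter) and so shows that the arrangement of the methyls alone changes the number, with no atom gained or lost. The earlier compounds shown here differ in more than one place and could not isolate this. Nothing measured here accounts for the step.

Going by these compounds, what a chlorine or a hydroxyl in place of either methyl would do stays open. So does whether the same shift gives a step of like size with the longer chain of compound 2.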